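Swapping the aryl group on the oxadiazole of compound 3

The source may hold more compounds than are shown below. What is called first, only, known or untested is meant among the compounds shown, and "the series" means these compounds.

Compound 3, with the structure `CC(O)(CS(=O)(=O)c1ccc(Br)cc1)c1nc(-c2ccc(Cl)cc2)no1`, was tested in a functional assay on DU-145 cells (Homo sapiens) for cytotoxicity, read by MTT assay; on this read-out higher numbers stand for weaker inhibition and lower numbers for stronger inhibition. There compound 3 gives > 100000 nM, which is a limit of the assay rather than a measured number. Compound 1, with the structure `CC(O)(CS(=O)(=O)c1ccc(F)cc1)c1nc(-c2ccc(F)c(Cl)c2)no1`, gives > 100000 nM in this assay, again a limit; the shared ceiling is the limit of > 100000 nM in this assay, at which 2 of the 3 values shown sit. Compound 2, with the structure `CC(O)(CS(=O)(=O)c1ccc(Cl)cc1)c1nc(-c2ccc(F)c(Cl)c2)no1`, gives 35500 nM in this assay. Going by the values given here, the only measured step is an at least 2.8-fold lower number from compound 1 to compound 2 (0.44 log units; beyond the scatter), and it concerns the halogen on the sulfonyl-bearing ring, not the ring on the oxadiazole.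

Compound 4, with the structure `CC(O)(CS(=O)(=O)c1ccc(Br)cc1)c1nc(-c2ccc(F)c(Cl)c2)no1`, differs from compound 3 in one place: 3-chloro-4-fluorophenyl in place of 4-chlorophenyl on an aromatic carbon. No measured step touches this position, so the direction of the change cannot be read from the numbers shown; what is known is that compound 2, which carries this same 3-chloro-4-fluorophenyl, gives 35500 nM. The step from compound 3 to compound 4 in this assay is therefore expected to be small, an at least 1.6-fold lower number from compound 3 to compound 4 (0.22 log units; that floor lies within the scatter). Compound 4 is estimated at 60000 nM, with a range from 20000 nM to 200000 nM.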

Compound 4, half-maximal inhibitory concentration: 75000 nM
Beside the measured number, compound 4's estimate is 1.3-fold (0.10 log units) below it; the range from low to high includes it.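

With 3-chloro-4-fluorophenyl in place of 4-chlorophenyl at this position, this assay shows an at least 1.3-fold lower number from compound 3 to compound 4 (0.12 log units; that floor lies within the scatter), so the swap brings no firm gain. That step and an at least 1.3-fold lower number from compound 1 to compound 4 (0.12 log units; that floor lies within the scatter) are only floors because compound 3 and compound 1 each sit at a limit of the assay: the limit of > 100000 nM in this assay, at which 2 of the 4 values shown sit.

The clearer finding concerns the halogen on the sulfonyl-bearing ring, with 3-chloro-4-fluorophenyl held fixed: a 2.1-fold higher number from compound 2 to compound 4 (0.32 log units; beyond the scatter), which leaves chloro with the lowest number among the fluoro, chloro and bromo compounds 1, 2 and 4.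

On these data alone, it remains open which of the two halogens on 3-chloro-4-fluorophenyl matters, if either does. As far as these compounds go, it is also open whether an amine or a carboxylic acid on that ring would bring the number down further.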